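Adding a chloro group to compound 2

The source may hold more compounds than are shown below. What is called first, only, known or untested is meant among the compounds shown, and "the series" means these compounds.

Of the compounds shown here, two have been measured so far in a functional assay on MOLT-4 cells (Homo sapiens) for inhibition, with a stated time of 48 h; on this read-out higher numbers stand for weaker inhibition of growth and lower numbers for stronger inhibition of growth. There, compound 1 (`COc1c(C(=O)/C=C/c2ccc(Cl)cc2)c(O)c(Br)c2occc12`) gives 2090 nM and compound 2 (`C=CCc1c(O)c(C(=O)/C=C/c2ccccc2)c(OC)c2ccoc12`) gives 2170 nM. These two values lie within the usual scatter of each other, so compound 2 stands level with compound 1 and no order can be read between them.

Compound 3 (`C=CCc1c(O)c(C(=O)/C=C/c2ccc(Cl)cc2)c(OC)c2ccoc12`) departs from compound 2 in one place: chloro in place of hydrogen on an aromatic carbon. Phenyl becomes 4-chlorophenyl, with chloro in place of hydrogen on an aromatic carbon, para to a large group. Going by the values given here, no measured pair isolates this change. Compound 1 already carries the 4-chlorophenyl group, but its core differs from that of compound 2 in other ways as well. It still offers a weak guide, since compound 1 with that group gives 2090 nM, which gives no sign of a large shift. In this assay the expected change is therefore small, a 1.4-fold lower number from compound 2 to compound 3 (0.13 log units; within the scatter), leaning slightly toward stronger inhibition of growth but within the scatter. For compound 3 the estimated value is 1600 nM, with an expected range from 650 nM to 3800 nM.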

Compound 3, concentration for 50% growth inhibition: 2610 nM
For compound 3 the middle estimate is 1.6-fold (0.21 log units) below the measured one, and the stated range covers the measured number.
By their numbers in this assay, from the lowest: compounds 1, 2 and 3 (each within the scatter of the next).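

In this assay, going by these compounds alone, the first direct reading of chloro in place of hydrogen on an aromatic carbon, para to a large group, is a 1.2-fold higher number from compound 2 to compound 3 (0.08 log units; within the scatter), so phenyl and 4-chlorophenyl cannot be told apart on this read-out when they sit on the core of compound 2. The exchange of allyl in place of bromo on an aromatic carbon, with 4-chlorophenyl present on both sides, reads a 1.2-fold higher number from compound 1 to compound 3 (0.10 log units; within the scatter), so neither of these two single exchanges moves the number beyond the scatter. Nothing measured here bears on why these numbers stay so close.

What remains open is whether this position responds to anything at all, since chloro is the only group shown there besides hydrogen, and an amine or a carboxylic acid in the same place could give a different answer. As far as these compounds go, it is equally open whether the allyl position has any influence on growth inhibition, as a longer chain or an amine there would test, and whether the flat result with chloro holds in any other cell line.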